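The source may hold more compounds than are shown below. What is called first, only, known or untested is meant among the compounds shown, and "the series" means these compounds.

In a functional assay on HCT-116 cells (Homo sapiens) for antiproliferative activity, read by MTT assay, with a stated time of 48 h (a lower number here means a stronger inhibitor, a higher number a weaker inhibitor), compound 1 (`Cc1c(C(=O)NCC(O)CO)oc2ccc(N(Cc3ccc(Br)cc3)S(=O)(=O)c3ccc(Br)cc3)cc12`) gives 27800 nM. Compound 2 (`Cc1ccc(NC(=O)c2oc3ccc(N(Cc4ccc(Br)cc4)S(=O)(=O)c4ccc(Br)cc4)cc3c2C)nc1`) stands at > 40000 nM, which is a limit and not a number.

Compound 3 (`Cc1c(C(=O)NCCNc2ccccc2)oc2ccc(N(Cc3ccc(Br)cc3)S(=O)(=O)c3ccc(Br)cc3)cc12`) carries 2-anilinoethyl in place of 5-methylpyridin-2-yl on an amide-type nitrogen.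

Within the data shown here, the only measured step at this nitrogen is an at least 1.4-fold higher number from compound 1 to compound 2 (0.15 log units; that floor lies within the scatter). It gives a floor and not a true size, so no step beyond the scatter is expected in this assay, in either direction. Among the measured compounds shown here, compound 1 at 27800 nM holds the only true number, so a weak result is expected again, close to that number.

The expected step is an at least 1.3-fold lower number from compound 2 to compound 3 (0.12 log units; that floor lies within the scatter). For compound 3 the estimate is 30000 nM, with an expected range of 12000 nM to 60000 nM.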

Compound 3, half-maximal inhibitory concentration: > 40000 nM
Compound 3 ended at the assay's limit; the forecaster's own chance of this, stated with the estimate: 45%; middle value at least 1.3-fold (0.12 log units) away from the limit.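

In this assay compound 3 gives a limit and not a number, so two groups with a six-membered aromatic ring on the amide-type nitrogen, 5-methylpyridin-2-yl in compound 2 and 2-anilinoethyl in compound 3, now leave no readable value. Compound 1, with 2,3-dihydroxypropyl, is the only one of the three with a true number, but the new comparison gives only a floor: an at least 1.4-fold higher number from compound 1 to compound 3 (0.15 log units; that floor lies within the scatter). The step between compound 2 and compound 3 cannot be read, since both stand at a limit: the limit of > 40000 nM in this assay, at which 2 of the 3 values shown sit.

On these data alone, how far compound 2 and compound 3 lie past that limit stays open. Also open, as far as these compounds go, is whether a group on this nitrogen, such as a carboxylic acid or a longer chain ending in an amine, gives a clearly lower number than compound 1.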